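Benzoyl in place of acetyl on the nitro-substituted ester

The compounds below may be only part of what the source reports. "The series", "measured", "known", "first", "only" and "open" are said of these compounds alone.

Measured so far in a functional assay on HBL-100 cells (Homo sapiens) for inhibition, read by sulforhodamine B assay, with a stated time of 48 h; on this read-out higher numbers stand for weaker inhibition of growth and lower numbers for stronger inhibition of growth:
compound 1 `O=C(OC/C(=C\c1ccccc1[N+](=O)[O-])C(=O)c1ccccc1)c1ccccc1` gives 3900 nM
compound 2 `CC(=O)OC/C(=C/c1ccccc1Cl)C(=O)c1ccccc1` gives 21000 nM
compound 3 `CC(=O)OC/C(=C/c1ccccc1[N+](=O)[O-])C(=O)c1ccccc1` gives a limit only

For compound 3 this assay reports no number but a limit, > 100000 nM. Within the data shown here, the one measured single-point step, an at least 4.7-fold higher number from compound 2 to compound 3 (0.67 log units; beyond the scatter), concerns a different change and so says nothing directly about the change considered here. Compound 4 `O=C(OC/C(=C/c1ccccc1[N+](=O)[O-])C(=O)c1ccccc1)c1ccccc1` differs from compound 3 by phenyl in place of methyl on a carbonyl carbon. Among the measured compounds shown here, no measured step matches this change; the only pointer is compound 1, which also carries a benzoyloxy group and gives 3900 nM in this assay. Compound 4 is therefore expected to come in under the limit of compound 3, at an estimated 40000 nM (range 8000 nM to 200000 nM), which would mean an expected step of an at least 2.5-fold lower number from compound 3 to compound 4 (0.39 log units; beyond the scatter).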

Compound 4, concentration for 50% growth inhibition: > 100000 nM
Compound 4: a limit, no number (the forecaster's own chance of this, stated with the estimate: 35%); middle value at least 2.5-fold (0.39 log units) away from the limit.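

In this assay the change from acetyl to benzoyl cannot be read, since compound 3 and compound 4 each give only a limit: the limit of > 100000 nM in this assay, at which 2 of the 4 values shown sit. What the new result does show concerns the double bond: drawing it Z rather than E goes with an at least 25-fold higher number from compound 1 to compound 4 (1.40 log units; beyond the scatter) and nothing else separates this pair: the fact that compounds 1 and 4 differ only in the configuration as drawn. Still open, going by these compounds, is whether benzoyl and acetyl differ when the double bond is drawn E, and how a longer chain such as butanoyl or a group carrying an amine would behave in place of acetyl.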